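Sulfonyl substituent change from compound 3 to compound 4

This account rests on a few compounds, and the source may have more. Where it says the series, first, only, none or still open, it means among the compounds named here.

In a functional assay on NCI-H1975 cells (Homo sapiens) for inhibition, read by sulforhodamine B assay, tested at 10 uM (a lower number here means less inhibition, a higher number more inhibition at the concentration tested (going by the name of the read-out)), the measured compounds stand as follows. Compound 1 `CN1CCN(c2ccc(C3=NNC(c4ccc(N(C)C)cc4)C3)cc2)CC1` gives 2.4%. Compound 2 `CC(=O)N1N=C(c2ccc(N3CCN(C)CC3)cc2)CC1c1ccc(N(C)C)cc1` gives -1.9%. Compound 3 `CN1CCN(c2ccc(C3=NN(S(=O)(=O)C4CC4)C(c4ccc(N(C)C)cc4)C3)cc2)CC1` gives 0.2%.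

Compound 3 holds the second highest of the three numbers, with a number 2.1 percentage points higher from compound 2 to compound 3 (within the scatter) and a number 2.2 percentage points lower from compound 1 to compound 3 (within the scatter). Compound 4 `CN1CCN(c2ccc(C3=NN(S(=O)(=O)c4ccc(Br)cc4)C(c4ccc(N(C)C)cc4)C3)cc2)CC1` differs from compound 3 by 4-bromophenyl in place of cyclopropyl on a sulfonyl sulfur. Going by the values given here, no measured step touches the group on the sulfonyl sulfur; the steps available, a number 4.3 percentage points lower from compound 1 to compound 2 (within the scatter), a number 2.2 percentage points lower from compound 1 to compound 3 (within the scatter) and a number 2.1 percentage points higher from compound 2 to compound 3 (within the scatter), all vary the group on the ring nitrogen and all lie within the scatter. No step beyond the scatter is therefore expected for compound 4, whose value is estimated at 1%, ranging from -9% to 11%, meaning an expected step of a number 0.8 percentage points higher from compound 3 to compound 4 (within the scatter).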

Compound 4, a percentage reported as inhibition, at one concentration (the size of the read-out at that concentration, not a potency): 70.8%
Beside the measured number, compound 4's estimate is 69.8 percentage points below it; the whole stated range lies below it.
By their numbers in this assay, from the lowest: compounds 2, 3 and 1 (each within the scatter of the next); then compound 4.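

In this assay the group on the sulfonyl sulfur turns out to matter greatly: 4-bromophenyl in place of cyclopropyl gives a number 70.6 percentage points higher from compound 3 to compound 4 (beyond the scatter), although cyclopropylsulfonyl on the ring nitrogen had left compound 3 within the scatter of compound 1 and compound 2. A sulfonyl on that nitrogen is thus not enough in itself, and the (4-bromophenyl)sulfonyl group also stands clear of acetyl, with a number 72.7 percentage points higher from compound 2 to compound 4 (beyond the scatter), and of hydrogen, with a number 68.4 percentage points higher from compound 1 to compound 4 (beyond the scatter). The compounds shown leave open whether the bromine or the aromatic ring carries this step, which a plain phenyl or a 4-methoxyphenyl on the sulfur would separate. No evidence at hand explains the step.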